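A few compounds are considered here, and "the series" means these few. Any claim that something is new, unique, unknown or untested is made for them only; others in the source may bear on it.

Measured so far:
Compound 1, `O=C1CC(c2c[nH]c3cc(F)ccc23)C(=O)N1`: 3400 nM
Compound 2, `O=C1CC(c2c[nH]c3cc(Br)ccc23)C(=O)N1`: 420 nM

In an assay on isolated protein for inhibition of Indoleamine 2,3-dioxygenase 1 (Homo sapiens), with a stated time of 15 min (a lower number here means a stronger inhibitor, a higher number a weaker inhibitor), compound 1 gives 3400 nM and compound 2 gives 420 nM. Of these two numbers compound 2 holds the lower one, and its gap to compound 1 is beyond the scatter: an 8.1-fold lower number from compound 1 to compound 2 (0.91 log units; beyond the scatter). Compound 3, `COc1ccc2c(C3CC(=O)NC3=O)c[nH]c2c1`, has not yet been measured in this assay. It differs from compound 2 in one place: methoxy in place of bromo on an aromatic carbon. Within the data shown here, only one measured step bears on this change, an 8.1-fold lower number from compound 1 to compound 2 (0.91 log units; beyond the scatter), and that step swaps one halogen for another rather than a halogen for a methoxy. It shows that the group at this position can move the number by a modest amount, but it gives no direct reading on methoxy itself. A number somewhat higher than that of compound 2 is expected for compound 3, with considerable uncertainty about the size. The estimate for compound 3 in this assay is 1500 nM, with a range from 400 nM to 6000 nM, meaning an expected step of a 3.6-fold higher number from compound 2 to compound 3 (0.55 log units; beyond the scatter).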

Compound 3, half-maximal inhibitory concentration: > 50000 nM
Compound 3: only a limit was reported; the forecaster's own chance of this, stated with the estimate: 5%; at least 33-fold (1.52 log units) between middle value and limit.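

In this assay, compound 3 is reported only as a limit of the assay, not as a number: the limit of > 50000 nM in this assay, at which 1 of the 3 values shown sits. Even read as a limit, the change of bromo to methoxy on this aromatic carbon gives an at least 110-fold higher number from compound 2 to compound 3 (2.07 log units; beyond the scatter), and the change of fluoro to methoxy gives an at least 14-fold higher number from compound 1 to compound 3 (1.16 log units; beyond the scatter), so the group here can matter much more than the halogen swap alone showed, with an 8.1-fold lower number from compound 1 to compound 2 (0.91 log units; beyond the scatter). Methoxy therefore falls well behind both halogens in this assay, and although methoxy carries a hydrogen-bond acceptor that the bromo of compound 2 does not, the compounds shown cannot say whether that count has anything to do with the loss.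

Going by these compounds, how far compound 3 really lies from the other two stays unknown, and two halogens are too few to set a trend, so chloro and iodo would be needed to see whether the number keeps falling along the halogen series. A methyl or a hydroxyl at the same carbon would help separate what the carbon and the oxygen of methoxy each contribute, and an amine would test a different kind of group there.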